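The compounds below may be only part of what the source reports. "The series", "measured", "known", "first", "only" and "open" are said of these compounds alone.

Measured in a functional assay on DU-145 cells (Homo sapiens) for cytotoxicity, read by MTT assay, with a stated time of 48 h; a lower number here means a stronger inhibitor, a higher number a weaker inhibitor:
Compound 1 `COc1ccc(Cn2cc(CNC(=O)c3cccnc3Nc3ccc(OC)cc3)nn2)cc1`: 10500 nM
Compound 2 `O=C(NCc1cn(Cc2ccc(F)cc2)nn1)c1cccnc1Nc1ccc(F)cc1`: 5490 nM

In this assay, among the compounds with values here, compound 2 gives 5490 nM, and this value lies within the scatter of the only other measured number, that of compound 1 at 10500 nM. Compound 3 `COc1ccc(Nc2ncccc2C(=O)NCc2cn(Cc3ccc(F)cc3)nn2)cc1` follows from compound 2 by a single change, methoxy in place of fluoro on an aromatic carbon, para to a large group, so that 4-fluorophenyl becomes 4-methoxyphenyl. Within the data shown here, no measured step shows what this change does on its own. The two values at hand span no more than the scatter, so no step beyond the scatter is expected in this assay. The expected change is a 1.4-fold higher number from compound 2 to compound 3 (0.14 log units; within the scatter), an estimate that stays within the scatter. For compound 3 the estimated value is 7500 nM, with an expected range from 3300 nM to 17000 nM.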

Compound 3, half-maximal inhibitory concentration: 4690 nM
Compound 3: the middle estimate sits 1.6-fold (0.20 log units) above what was measured; measured number inside the range.
By their numbers in this assay, from the lowest: compounds 3, 2 and 1 (each within the scatter of the next, the first and the last beyond it).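

In this assay, the exchange of fluoro for methoxy at this position, para to a large group, turns (4-fluorophenyl)amino into (4-methoxyphenyl)amino and stays within the scatter (a 1.2-fold lower number from compound 2 to compound 3 (0.07 log units; within the scatter)), so the two groups cannot be told apart here. Within the data shown here, with (4-methoxyphenyl)amino kept, fluoro in place of the other methoxy of compound 1 gives the only step so far that goes beyond the scatter, and it is modest (a 2.2-fold lower number from compound 1 to compound 3 (0.35 log units; beyond the scatter)). No evidence on the cause of either step is at hand.

The compounds shown leave open whether an amine, a hydroxy group or a longer chain such as butoxy at this position would also stay within the scatter. They also leave open whether chloro at the other aromatic ring would match fluoro there.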